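Trimming the Side Chain of a Serotonin Receptor Agonist

This account rests on a few compounds, and the source may have more. Where it says the series, first, only, none or still open, it means among the compounds named here.

Three compounds built on one shared core were tested in a functional assay on CHO cells for activation of 5-hydroxytryptamine receptor 1D (Homo sapiens), read by GTPgammaS binding; on this read-out higher numbers stand for larger maximal responses and lower numbers for smaller maximal responses. Compound 1 `O=S(=O)(NCC1CCN(CCCc2c[nH]c3ccc(-n4cnnc4)cc23)CC1)c1ccccc1` gives 73%. Compound 2 `COC[C@H](NC1CCN(CCCc2c[nH]c3ccc(-n4cnnc4)cc23)CC1)c1ccccc1` gives 93%, a step of a number 20 percentage points higher from compound 1 to compound 2 (beyond the scatter). Compound 3 `NC(=O)OC[C@H](NC1CCN(CCCc2c[nH]c3ccc(-n4cnnc4)cc23)CC1)c1ccccc1` gives 73%, so the step of a number 20 percentage points lower from compound 2 to compound 3 (beyond the scatter) brought the response back level with compound 1, the two together forming the lowest pair of the three. Compound 4 `C[C@@H](NC1CCN(CCCc2c[nH]c3ccc(-n4cnnc4)cc23)CC1)c1ccccc1` differs from compound 3 in one place: 1-phenylethyl in place of 2-(carbamoyloxy)-1-phenylethyl on an amine nitrogen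
The step of a number 20 percentage points lower from compound 2 to compound 3 (beyond the scatter) bears most on this change; it likewise altered the group on an oxygen on a saturated carbon, and it was modest. Removing that carbamate altogether is expected to carry the response back toward compound 2, so compound 4 is estimated at 85%, between 65% and 100%, an expected step of a number 12 percentage points higher from compound 3 to compound 4 (beyond the scatter).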

Compound 4, largest response reached (reported as efficacy), in percent of the reference or control that the assay uses: 90%
For compound 4 the middle estimate is 5 percentage points below the measured one, and the stated range covers the measured number.
By their numbers in this assay, from the lowest: compounds 1 and 3 (each within the scatter of the next); then compounds 4 and 2 (each within the scatter of the next).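

In this assay, 1-phenylethyl in place of 2-(carbamoyloxy)-1-phenylethyl gives a number 17 percentage points higher from compound 3 to compound 4 (beyond the scatter) and in place of 2-methoxy-1-phenylethyl gives a number 3 percentage points lower from compound 2 to compound 4 (within the scatter) so on this amine nitrogen the response stays high without either oxygen-bearing group. The (1-phenylethyl)amino group in place of ((phenylsulfonyl)amino)methyl on a saturated ring carbon gives a number 17 percentage points higher from compound 1 to compound 4 (beyond the scatter) and so matches the gain seen on removing the carbamate. No measurement here explains these differences. On these data alone, it remains open whether 2-hydroxy-1-phenylethyl or 2-amino-1-phenylethyl on the same nitrogen would hold the response.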